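Trimming the phenyl of compound 2 to a methyl

The source may report more compounds than this note shows. Statements on the series, on what has been measured and on what is new or still open speak of the compounds shown alone.

Compound 1 `O=C(COc1ccc2cc(C(O)(C(F)(F)F)C(F)(F)F)c(O)cc2c1)Nc1ccc(-c2ccccc2)cc1` is the larger member of this small set; in an assay on isolated protein for inhibition of receptor-type tyrosine-protein phosphatase C (Homo sapiens), read by spectrophotometry (a lower number here means a stronger inhibitor, a higher number a weaker inhibitor), compound 1 gives 3400 nM. Compound 2 `Oc1ccc(-c2ccccc2)cc1C(O)(C(F)(F)F)C(F)(F)F` is far smaller. In this assay compound 2 gives only a limit, > 500000 nM, and no number. Compound 2 thus stands at the limit of > 500000 nM in this assay, at which 1 of the 2 values shown sits, with nothing measurable to show against compound 1.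

Compound 3 `Cc1ccc(O)c(C(O)(C(F)(F)F)C(F)(F)F)c1` has not been measured. It differs from compound 2 in one respect: methyl in place of phenyl on an aromatic carbon. The change removes the phenyl and leaves the rest of the molecule untouched, so compound 3 is a smaller fragment of a compound that already reached the limit.

Given that compound 2 shows only a limit, > 500000 nM, compound 3 is expected to fall in the same region. The step of a number no higher from compound 2 to compound 3 (the limit leaves the size open) is estimated to be none beyond the scatter. Compound 3 is estimated at 500000 nM, within 100000 nM to 2000000 nM, most probably reported again as a limit.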

Compound 3, half-maximal inhibitory concentration: 207000 nM
Beside the measured number, compound 3's estimate is 2.4-fold (0.38 log units) above it; the range from low to high includes it.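

In this assay, the phenyl para to a hydroxy group proves unnecessary for a measurable reading: with methyl in its place, compound 3 gives 207000 nM. Going from phenyl to methyl at this position gives an at least 2.4-fold lower number from compound 2 to compound 3 (0.38 log units; beyond the scatter), so the smaller group does not cost activity here but comes with a lower number, though the activity remains weak. On these data alone, the true size of this step stays unknown because compound 2 has only a limit and no number: the limit of > 500000 nM in this assay, at which 1 of the 3 values shown sits.

As far as these compounds go, it remains open whether the lower number comes from the methyl itself or simply from the loss of the phenyl, which a bare hydrogen, a chlorine atom or an ethyl group at this position could help separate. From the compounds shown here alone, whether a methoxy group or an amine would be accepted here is also open.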